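Swapping a Butyl for a Phenyl at the Ring Nitrogen

The source may hold more compounds than are shown below. What is called first, only, known or untested is meant among the compounds shown, and "the series" means these compounds.

Measured so far:
compound 1 `CCCCN1C(=O)CCN(S(=O)(=O)c2ccc(-n3nc(C(=O)O)cc3C)cc2)C1=S` gives 2%
compound 2 `CCCN1C(=O)CCN(S(=O)(=O)c2ccc(-n3nc(C)cc3C)cc2)C1=S` gives 1%
compound 3 `Cc1cc(C(=O)O)nn1-c1ccc(S(=O)(=O)N2CCC(=O)N(Cc3ccccc3)C2=S)cc1` gives 16%

In a functional assay on the whole organism (blood, strain albino) with Mus musculus as the target, with stated times of 6 days and 3 h, at a dose of 1 mmol/kg by the oral route (on this read-out higher numbers stand for more inhibition at the one dose given (going by the name of the read-out) and lower numbers for less inhibition), compound 1 gives 2%. Among the three measured compounds it stands second highest, though its gap to compound 2 lies within the scatter, so the two cannot be told apart. Compound 3 sits clearly above it: the step of a number 14 percentage points higher from compound 1 to compound 3 (beyond the scatter) is the only difference beyond the scatter seen here.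

The unmeasured compound 4 `Cc1cc(C(=O)O)nn1-c1ccc(S(=O)(=O)N2CCC(=O)N(c3ccccc3)C2=S)cc1` differs from compound 1 in one place: phenyl in place of butyl on an amide-type nitrogen in a ring. Going by the values given here, no measured pair shows exactly this change. The nearest guide is the step from compound 1 to compound 3, where a phenyl also entered at the same region of the shared core, though there on a saturated chain carbon bound to the ring nitrogen rather than on the nitrogen itself; that step was a number 14 percentage points higher from compound 1 to compound 3 (beyond the scatter), a modest rise.

On that basis compound 4 is expected to gain modestly, a step of a number 10 percentage points higher from compound 1 to compound 4 (within the scatter). Compound 4 is thus estimated at 12%, within a range from 0% to 30%.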

Compound 4, a percentage reported as inhibition, in the whole organism at one dose (the size of the read-out at that dose, not a potency): 1%
Beside the measured number, compound 4's estimate is 11 percentage points above it; the measured number falls inside the stated range.
By their numbers in this assay, from the lowest: compounds 2, 4 and 1 (each within the scatter of the next); then compound 3.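

In this assay the step of a number 1 percentage points lower from compound 1 to compound 4 (within the scatter) means that phenyl on the amide-type nitrogen cannot be told apart from butyl there, so this swap does not repeat the rise that benzyl gave. The step of a number 15 percentage points lower from compound 3 to compound 4 (beyond the scatter) separates phenyl from benzyl at the same nitrogen, showing that among these compounds having a phenyl ring at this position is not enough and that only the benzyl compound stands out. Nothing available here explains this difference.

Still open, going by these compounds, is whether a longer chain carrying the phenyl ring, such as 2-phenylethyl, would keep or lose what benzyl gives. Also open, on these data alone, is how an amine or a methoxy group on the phenyl ring of benzyl would read at this nitrogen.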